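Nitro in Place of Hydrogen: Compound 3 to Compound 4

A few compounds are considered here, and "the series" means these few. Any claim that something is new, unique, unknown or untested is made for them only; others in the source may bear on it.

Measured so far in an assay on mitochondria for inhibition of Amine oxidase [flavin-containing] A (Rattus norvegicus), tested at 100 uM; on this read-out lower numbers stand for less inhibition and higher numbers for more inhibition at the one concentration tested (going by the name of the read-out):
- compound 1 `C[C@H](NCc1ccc(OCc2ccc([N+](=O)[O-])cc2)cc1)C(N)=O`: 22%
- compound 2 `NC(=O)[C@@H](NCc1ccc(OCc2cccc(Cl)c2)cc1)c1ccccc1`: 33%
- compound 3 `NC(=O)[C@@H](NCc1ccc(OCc2ccccc2)cc1)c1ccccc1`: 35%

Among these three numbers compound 3 has the highest; its nearest neighbour is compound 2, which is within the scatter, and the furthest is compound 1, beyond the scatter. Compound 4 `NC(=O)[C@@H](NCc1ccc(OCc2ccc([N+](=O)[O-])cc2)cc1)c1ccccc1` has not yet been measured. It differs from compound 3 in one place: nitro in place of hydrogen on an aromatic carbon.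

Among the compounds with values here, only one measured step touches that same ring, the one from compound 2 to compound 3, where a chloro gives way to hydrogen: a number 2 percentage points higher from compound 2 to compound 3 (within the scatter). That step lies within the scatter, so swapping a single group on that ring did not move this assay noticeably. Compound 1 also carries a nitro on that ring but differs from compound 3 elsewhere as well, so its lower number cannot be read as the effect of the nitro alone. For compound 4 the step is expected to be small, a number 5 percentage points lower from compound 3 to compound 4 (within the scatter), with a slight lean downward because compound 1 gives 22%. Compound 4 is therefore estimated at 30%, between 15% and 45%.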

Compound 4, a percentage reported as inhibition, at one concentration (the size of the read-out at that concentration, not a potency): 16%
Beside the measured number, compound 4's estimate is 14 percentage points above it; the measured number falls inside the stated range.
By their numbers in this assay, from the lowest: compounds 4 and 1 (each within the scatter of the next); then compounds 2 and 3 (each within the scatter of the next).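

In this assay the group on this ring turns out to matter: the earlier chloro-to-hydrogen swap stayed within the scatter, whereas the nitro gives a number 19 percentage points lower from compound 3 to compound 4 (beyond the scatter) and, against the 3-chlorophenyl analogue, a number 17 percentage points lower from compound 2 to compound 4 (beyond the scatter) so 4-nitrophenyl stands apart from both other rings. With the nitro held in place, the change on the chain carbon gives a number 6 percentage points lower from compound 1 to compound 4 (within the scatter) so phenyl in place of methyl shows no clear shift, and the low numbers of the two nitro compounds go together. Nothing available here explains the drop.

The rings shown carry only hydrogen, chloro or nitro, so it stays open how an amine or a methoxy group at this place would read. Chloro appears only in 3-chlorophenyl, so the group and its position cannot yet be separated.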